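Swapping methyl for trifluoromethyl on the benzoyl ring

The source may hold more compounds than are shown below. What is called first, only, known or untested is meant among the compounds shown, and "the series" means these compounds.

Measured compounds:
- Compound 1 `O=C(/C=C/c1ccc2c(c1)B(O)OC2)c1cccs1`: 4600 nM
- Compound 2 `O=C(/C=C/c1ccc2c(c1)B(O)OC2)c1ccc(F)cc1`: 1600 nM
- Compound 3 `Cc1ccc(C(=O)/C=C/c2ccc3c(c2)B(O)OC3)cc1`: 6500 nM

Three compounds share a core and differ only in the ring attached to the carbonyl. In a functional assay on MDA-MB-231 cells (Homo sapiens) for cytotoxicity, read by MTT assay, with a stated time of 48 h (on this read-out higher numbers stand for weaker inhibition and lower numbers for stronger inhibition), compound 3 gives 6500 nM, the highest of the three numbers. The step of a 1.4-fold higher number from compound 1 to compound 3 (0.15 log units; within the scatter) lies within the scatter, so compound 3 and compound 1 cannot be told apart, whereas the step of a 4.1-fold higher number from compound 2 to compound 3 (0.61 log units; beyond the scatter) is beyond it, so compound 3 is clearly weaker than compound 2.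

Compound 4 `O=C(/C=C/c1ccc2c(c1)B(O)OC2)c1ccc(C(F)(F)F)cc1` is not yet measured. It differs from compound 3 by trifluoromethyl in place of methyl on an aromatic carbon.

Going by the values given here, no measured step exchanges methyl for trifluoromethyl. The nearest guide is the step of a 4.1-fold higher number from compound 2 to compound 3 (0.61 log units; beyond the scatter), where a fluoro group on the same aromatic carbon gave a modestly lower number than methyl; the step of a 2.9-fold lower number from compound 1 to compound 2 (0.46 log units; beyond the scatter) also shows the fluoro compound giving the lowest number. Because of a 4.1-fold higher number from compound 2 to compound 3 (0.61 log units; beyond the scatter), a modest step downward in this assay is expected for compound 4, though the guide is indirect.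

Compound 4 is therefore estimated at 3500 nM, with a range from 1200 nM to 10000 nM, meaning an expected step of a 1.9-fold lower number from compound 3 to compound 4 (0.27 log units; within the scatter).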

Compound 4, half-maximal inhibitory concentration: 9200 nM
The estimate for compound 4 lay 2.6-fold (0.42 log units) below the measured number, within the range that was stated.
By their numbers in this assay, from the lowest: compound 2; then compounds 1, 3 and 4 (each within the scatter of the next).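

In this assay, trifluoromethyl in place of methyl on this aromatic carbon gives a 1.4-fold higher number from compound 3 to compound 4 (0.15 log units; within the scatter), so at this position the two groups cannot be told apart, even though three fluorine atoms enter with the change. Fluorine in the group is therefore not enough to give the lower number seen with compound 2: trifluoromethyl in place of fluoro gives a 5.8-fold higher number from compound 2 to compound 4 (0.76 log units; beyond the scatter), which leaves compound 2 clearly apart from compound 4, just as it stands apart from compound 3. No separate measurement bears on why fluoro differs from the other two groups at this position.

A chloro group, a methoxy group or an amine on the same aromatic carbon would show whether compound 2 is a lone exception or one of several compounds with a lower number. The compounds shown also leave open whether fluoro would keep its lower number if the shared core were changed.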